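A few compounds are considered here, and "the series" means these few. Any claim that something is new, unique, unknown or untested is made for them only; others in the source may bear on it.

Measured in a functional assay on UO-31 cells (Homo sapiens) for antiproliferative activity, read by sulforhodamine B assay, with a stated time of 72 h; on this read-out lower numbers stand for stronger inhibition and higher numbers for weaker inhibition 
compound 1 `S=C(NNc1nncc2ccccc12)Nc1ccccc1` gives 56 nM 
compound 2 `O=S(=O)(Nc1ncccn1)c1ccc(Nc2nncc3ccccc23)cc1` gives 23 nM 
compound 3 `Clc1ccc(C(/C=C/c2ccccc2)=N\Nc2nncc3ccccc23)cc1` gives 6.2 nM 

Compound 2 takes the middle place among these three. Its number is lower than that of compound 1 and higher than that of compound 3, and both gaps lie beyond the scatter. The next compound, compound 4 `Cc1cc(NS(=O)(=O)c2ccc(Nc3nncc4ccccc34)cc2)no1`, is still unmeasured. It differs from compound 2 in one place, with 5-methyl-1,2-oxazol-3-yl in place of pyrimidin-2-yl on a sulfonamide nitrogen. A six-membered aromatic ring leaves and a five-membered aromatic ring enters, and neither group carries a net charge.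

For the measured compounds named here, no pair of measured compounds shows this change directly, so the expectation rests on compound 2 at 23 nM as its starting point. The three measured compounds differ far more widely in structure, yet their values run only from compound 1 at 56 nM to compound 3 at 6.2 nM in this assay as a whole. A change in this one group is therefore expected to give no step beyond the scatter, in either direction. The estimated change is a 1.1-fold higher number from compound 2 to compound 4 (0.04 log units; within the scatter) and no more than that. The estimate for compound 4 is 25 nM within an expected range of 9 nM to 70 nM in this assay.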

Compound 4, half-maximal inhibitory concentration: 33 nM
Compound 4: the middle estimate sits 1.3-fold (0.12 log units) below what was measured; the range from low to high includes it.
By their numbers in this assay, from the lowest: compound 3; then compounds 2, 4 and 1 (each within the scatter of the next, the first and the last beyond it).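

In this assay, this first pair of compounds differing in one place gives a step that can be read directly: a 1.4-fold higher number from compound 2 to compound 4 (0.16 log units; within the scatter). On the sulfonamide nitrogen, therefore, a 5-methyl-1,2-oxazol-3-yl group can take the place of a pyrimidin-2-yl group without a step beyond the scatter, even though a five-membered aromatic ring replaces a six-membered one and the hetero atoms of the ring are not the same; the two groups have the same counts of heavy atoms, hydrogen-bond donors and hydrogen-bond acceptors, and neither carries a net charge. Nothing measured on these compounds speaks to what lies behind this result.

Both groups compared here are aromatic rings, so the compounds shown leave open how the number would respond to a non-aromatic group on the same nitrogen, such as a cyclohexyl ring, an acetyl group or a plain hydrogen. They also leave open whether this exchange of rings would read the same way in other cell lines.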